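Three Triazole-Linked Analogues and an Ester-to-Amide Question

A few compounds are considered here, and "the series" means these few. Any claim that something is new, unique, unknown or untested is made for them only; others in the source may bear on it.

Of the compounds shown here, three sharing one core have been measured in an assay on isolated protein (Mus musculus) for inhibition of IL15-IL15 receptor (Homo sapiens), read by resazurin assay, with stated times of 30 min and 2.5 days; a higher number here means a weaker inhibitor, a lower number a stronger inhibitor. Compound 1 `Cn1c(Cc2nn(C)c(=O)c3ccccc23)nnc1SCCCCCCCC(=O)Nc1ccc(O)cc1O` gives 17000 nM in this assay. Compound 2 `Cn1c(Cc2nn(C)c(=O)c3ccccc23)nnc1SCCCCCCCCCCC(=O)Oc1ccc(Cl)cc1Cl`, which carries a longer chain ending in an ester, gives 8700 nM. Compound 3 `CC(C)COc1ccc(NC(=O)CSc2nnc(Cc3nn(C)c(=O)c4ccccc34)n2C)cc1`, with a much shorter linker and an amide, gives 30000 nM in this assay.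

Compound 2 has the lowest number of the three. Its gap to compound 1 is within the usual scatter of such measurements, so the two cannot be ranked against each other; its gap to compound 3 lies beyond the scatter.

The unmeasured compound 4 `Cn1c(Cc2nn(C)c(=O)c3ccccc23)nnc1SCCCCCCCCCCC(=O)Nc1ccc(Cl)cc1Cl` is compound 2 with a single change: (2,4-dichlorophenyl)amino in place of 2,4-dichlorophenoxy on a carbonyl carbon In plainer words, the ester that links the long chain to the dichlorinated ring is replaced by an amide, leaving the chain, the ring and its chlorines untouched.

Among the compounds with values here, no measured pair here shows what an ester-to-amide swap at this position does, so no direction can be read off from the data. Given that, compound 4 is expected to stay close to compound 2, with the estimated step from compound 2 to compound 4 being a 1.1-fold lower number from compound 2 to compound 4 (0.04 log units; within the scatter). The estimate for compound 4 in this assay is 8000 nM, expected to fall between 3000 nM and 25000 nM.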

Compound 4, half-maximal inhibitory concentration: 3300 nM
For compound 4 the middle estimate is 2.4-fold (0.38 log units) above the measured one; measured number inside the range.
By their numbers in this assay, from the lowest: compound 4; then compounds 2, 1 and 3 (each within the scatter of the next, the first and the last beyond it).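

In this assay, within the data shown here, placing (2,4-dichlorophenyl)amino instead of 2,4-dichlorophenoxy on the carbonyl carbon gives a 2.6-fold lower number from compound 2 to compound 4 (0.42 log units; beyond the scatter), and this is the only comparison here between compounds that differ in one place. It shows that the read-out responds to the atom joining the carbonyl to the dichlorinated ring, and that the ester is not needed to reach the lowest number in this small set: with the chain, ring and chlorines unchanged, the amide form gives a lower number than the ester. The swap replaces a group with a hydrogen-bond acceptor by one with a hydrogen-bond donor, yet no measurement shown here connects that difference in counts to the step.

Going by these compounds, it remains open whether the amide hydrogen itself matters, which an amide carrying a methyl group on its nitrogen, or a ketone at the same place, could help to test. On these data alone, compounds 1 and 3 differ from compound 4 in more than one place, so whether the same swap gives a similar step with a shorter or longer chain, or with a ring carrying methoxy groups instead of chlorines, also stays unknown.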